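Swapping the Aryl Ether in a Thromboxane Synthase Inhibitor

A few compounds are considered here, and "the series" means these few. Any claim that something is new, unique, unknown or untested is made for them only; others in the source may bear on it.

Of the compounds shown here, two have been measured in an assay for inhibition of Thromboxane-A synthase (Homo sapiens), using microsomes; a lower number here means a stronger inhibitor, a higher number a weaker inhibitor. Compound 1, with structure `O=C(O)CC/C=C\CC1COC(c2ccco2)OC1c1cccnc1`, gives 164 nM in this assay. Compound 2, with structure `COc1ccc(OC(C)(C)C2OCC(C/C=C\CCC(=O)O)C(c3cccnc3)O2)cc1`, gives 41 nM in this assay, the lower of the two numbers and therefore the stronger inhibitor; the gap between the two values lies beyond the usual scatter, but the two structures differ in more than one place, so the values alone are all that can be said of that pair.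

Compound 3, with structure `CSc1ccccc1OC(C)(C)C1OCC(C/C=C\CCC(=O)O)C(c2cccnc2)O1`, has not yet been measured. It differs from compound 2 in a single change: 2-(methylsulfanyl)phenyl in place of 4-methoxyphenyl on an oxygen on a saturated carbon. No measured pair shows a step of this kind, so there is no shown step to lean on. The change keeps the count of heavy atoms and of hydrogen-bond acceptors, and the expectation is a step from compound 2 to compound 3 of a 1.5-fold higher number from compound 2 to compound 3 (0.17 log units; within the scatter), most likely no larger than the scatter of this assay. Compound 3 is accordingly expected to give about 60 nM in this assay, within a range from 20 nM to 200 nM.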

Compound 3, half-maximal inhibitory concentration: 36 nM
For compound 3 the middle estimate is 1.7-fold (0.22 log units) above the measured one; low and high end bracket the measured number.
By their numbers in this assay, from the lowest: compounds 3 and 2 (each within the scatter of the next); then compound 1.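

In this assay, putting 2-(methylsulfanyl)phenyl in place of 4-methoxyphenyl on an oxygen on a saturated carbon gives a 1.1-fold lower number from compound 2 to compound 3 (0.06 log units; within the scatter). Within the data shown here, this is the first comparison here in which only one place differs, and it shows that this position accepts the exchange without a readable change in the assay: compound 2 and compound 3 cannot be told apart by their numbers. No measurement shown here explains why the two groups give such similar values.

The swap alters two things at once, the atom linking the methyl group to the ring, sulfur for oxygen, and where that group stands on the ring, so the near-equal values cannot be assigned to either alteration or to a cancelling of the two. A 2-methoxyphenyl or a 4-(methylsulfanyl)phenyl group at the same place would separate these two alterations, while an unsubstituted phenyl group would test whether the ring needs any such group at all.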